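From anilino to (4-acetylphenyl)amino: a small step expected

The source may report more compounds than this note shows. Statements on the series, on what has been measured and on what is new or still open speak of the compounds shown alone.

Compound 1 `COc1cc(Nc2nc(Nc3ccc(C)cc3)nnc2Cl)cc(OC)c1OC`: 14300 nM
Compound 2 `COc1cc(Nc2nc(Nc3ccc(Br)cc3)nnc2Cl)cc(OC)c1OC`: 8990 nM
Compound 3 `COc1cc(Nc2nc(Nc3ccccc3)nnc2Cl)cc(OC)c1OC`: 9750 nM

In a functional assay on PC-3 cells (Homo sapiens) for inhibition, read by MTT assay, with a stated time of 48 h (a lower number here means a stronger inhibitor, a higher number a weaker inhibitor), compound 3 gives 9750 nM, which lies within the scatter of the other two values. Compound 4 `COc1cc(Nc2nc(Nc3ccc(C(C)=O)cc3)nnc2Cl)cc(OC)c1OC` differs from it in one group: acetyl in place of hydrogen on an aromatic carbon, para to a large group. Three measured steps at that same place bear on this change: a 1.5-fold lower number from compound 1 to compound 3 (0.17 log units; within the scatter), a 1.1-fold higher number from compound 2 to compound 3 (0.04 log units; within the scatter) and a 1.6-fold lower number from compound 1 to compound 2 (0.20 log units; within the scatter). All three stay within the scatter, but none involves acetyl, so the evidence is indirect. No shift beyond the scatter is therefore expected in this assay. The expected step is a 1.0-fold higher number from compound 3 to compound 4 (0.01 log units; within the scatter). The estimated value for compound 4 is 10000 nM, with an expected range from 4500 nM to 20000 nM.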

Compound 4, half-maximal inhibitory concentration: 38600 nM
The estimate for compound 4 lay 3.9-fold (0.59 log units) below the measured number; the measured number lies above the stated range.
By their numbers in this assay, from the lowest: compounds 2, 3 and 1 (each within the scatter of the next); then compound 4.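

In this assay, within the data shown here, the three earlier groups at this place, methyl, bromo and hydrogen, gave numbers within the scatter of one another, and acetyl is the first group here to shift the number beyond it. Acetyl gives a 4.0-fold higher number from compound 3 to compound 4 (0.60 log units; beyond the scatter) and, in place of bromo, a 4.3-fold higher number from compound 2 to compound 4 (0.63 log units; beyond the scatter) and, in place of methyl, a 2.7-fold higher number from compound 1 to compound 4 (0.43 log units; beyond the scatter) so compound 4 is the weakest of the four. Nothing measured here accounts for this shift.

On these data alone, whether an amine, a carboxylic acid or a longer ketone chain at this place would raise the number as acetyl does remains open.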